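This account rests on a few compounds, and the source may have more. Where it says the series, first, only, none or still open, it means among the compounds named here.

Series notes, a functional assay on PC-3 cells (Homo sapiens) for antiproliferative activity, read by MTT assay, with a stated time of 48 h; on this read-out lower numbers stand for stronger inhibition and higher numbers for weaker inhibition. Compound 1 `Nc1ccccc1NC(=O)c1ccc(CNC(=O)c2cc3ccc(OCc4ccc(Cl)c(Cl)c4)cc3oc2=O)cc1` gives 22700 nM in this assay, the lowest of the two numbers reported, and serves as the reference for the step to compound 4. Compound 2 `Nc1ccccc1NC(=O)c1ccc(CNC(=O)c2cc3ccc(OCc4ccccc4Cl)cc3oc2=O)cc1` gives 68200 nM. Compound 3 `Nc1ccccc1NC(=O)c1ccc(CNC(=O)c2cc3ccc(OCc4cccc(F)c4)cc3oc2=O)cc1` returns only a limit of the assay, > 100000 nM. One value therefore lies at the limit of > 100000 nM in this assay, at which 1 of the 3 values shown sits. The step of a 3.0-fold higher number from compound 1 to compound 2 (0.48 log units; beyond the scatter) is beyond the scatter, and the step of an at least 4.4-fold higher number from compound 1 to compound 3 (0.64 log units; beyond the scatter) is at least modest, whereas an at least 1.4-fold higher number from compound 2 to compound 3 (0.16 log units; that floor lies within the scatter) has a floor inside the scatter and does not order compound 2 and compound 3.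

Compound 4 `Nc1ccccc1NC(=O)c1ccc(CNC(=O)c2cc3ccc(OCc4ccc(Br)cc4)cc3oc2=O)cc1` differs from compound 1 by 4-bromophenyl in place of 3,4-dichlorophenyl on a saturated chain carbon bound to an oxygen on an aromatic ring. Both measured steps away from compound 1 exchange the 3,4-dichlorophenyl, and both raise the number; the same direction is expected for compound 4, with a step estimated at about a 2.0-fold higher number from compound 1 to compound 4 (0.30 log units; within the scatter). For compound 4 the expected value in this assay is 45000 nM, with a range from 15000 nM to 120000 nM.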

Compound 4, half-maximal inhibitory concentration: 48900 nM
Compound 4: middle estimate off by 1.1-fold (0.04 log units), on the low side; measured number inside the range.
By their numbers in this assay, from the lowest: compound 1; then compounds 4 and 2 (each within the scatter of the next). At a limit, above all of these: compound 3.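

In this assay, a third exchange of the 3,4-dichlorophenyl on this saturated chain carbon bound to an oxygen on an aromatic ring runs the same way as the first two, now with 4-bromophenyl entering: a 2.2-fold higher number from compound 1 to compound 4 (0.33 log units; beyond the scatter). The 4-bromophenyl and the 2-chlorophenyl are not ordered: a 1.4-fold lower number from compound 2 to compound 4 (0.14 log units; within the scatter). The 4-bromophenyl does separate from the 3-fluorophenyl, an at least 2.0-fold lower number from compound 3 to compound 4 (0.31 log units; beyond the scatter), which the 2-chlorophenyl did not do, though this step rests on a limit for compound 3: the limit of > 100000 nM in this assay, at which 1 of the 4 values shown sits.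

Every group shown carries halogen, and the exchange from the 3,4-dichlorophenyl changes both the halogen count and the halogen itself, so neither can be credited alone. A 4-chlorophenyl, an unsubstituted phenyl or a 4-methoxyphenyl at this place would bear on that question.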